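Swapping an isopropyl for an iodine on a urea series

The compounds below may be only part of what the source reports. "The series", "measured", "known", "first", "only" and "open" are said of these compounds alone.

Compound 1: `COc1cccc(-n2cc(COc3cccc(NC(=O)Nc4ccc(Cl)c(C(F)(F)F)c4)c3)nn2)c1`, 1310 nM
Compound 2: `Cc1cccc(-n2cc(COc3cccc(NC(=O)Nc4ccc(Cl)c(C(F)(F)F)c4)c3)nn2)c1`, 7270 nM
Compound 3: `CC(C)c1ccc(-n2cc(COc3cccc(NC(=O)Nc4ccc(Cl)c(C(F)(F)F)c4)c3)nn2)cc1`, 2470 nM

These three compounds share one core and differ only in the group carried on the aromatic nitrogen. In a functional assay on HepG2 cells (Homo sapiens) for inhibition, read by MTT assay, with a stated time of 72 h (on this read-out lower numbers stand for stronger inhibition and higher numbers for weaker inhibition), compound 3 stands second highest of the three numbers. Its nearest neighbour is compound 1, and the step of a 1.9-fold higher number from compound 1 to compound 3 (0.28 log units; within the scatter) lies within the scatter, so the two cannot be ranked. Its furthest neighbour is compound 2, and the step of a 2.9-fold lower number from compound 2 to compound 3 (0.47 log units; beyond the scatter) is beyond the scatter, though still modest. The third step, a 5.5-fold higher number from compound 1 to compound 2 (0.74 log units; beyond the scatter), is also modest.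

Compound 4 is `O=C(Nc1cccc(OCc2cn(-c3ccc(I)cc3)nn2)c1)Nc1ccc(Cl)c(C(F)(F)F)c1`. It differs from compound 3 by iodo in place of isopropyl on an aromatic carbon, at the position para to a large group. For the measured compounds named here, none of the measured steps puts an iodo in place of an isopropyl, so nothing bears directly on this change. What the measured steps do show is that swapping the group on this ring has moved this assay by modest amounts in both directions, never by a large one. A step of similar size at most is therefore expected, with no clear direction.

On that basis compound 4 is estimated at 2500 nM, within a range from 900 nM to 7000 nM, meaning an expected step of a 1.0-fold higher number from compound 3 to compound 4 (0.01 log units; within the scatter).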

Compound 4, half-maximal inhibitory concentration: 2690 nM
Estimate against measurement, compound 4: 1.1-fold (0.03 log units) below; low and high end bracket the measured number.
By their numbers in this assay, from the lowest: compounds 1, 3 and 4 (each within the scatter of the next, the first and the last beyond it); then compound 2.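

In this assay, for the compounds shown here, the change from isopropyl, with its three carbons, to iodo, a single iodine, at the position para to a large group gives a 1.1-fold higher number from compound 3 to compound 4 (0.04 log units; within the scatter) and so the two groups cannot be ranked, which is the first reading of a swap at this position alone. Compound 4 also relates to the other compounds much as compound 3 does: a 2.7-fold lower number from compound 2 to compound 4 (0.43 log units; beyond the scatter) is beyond the scatter but modest, and a 2.1-fold higher number from compound 1 to compound 4 (0.31 log units; beyond the scatter) is modest too, though it lies just beyond the scatter while a 1.9-fold higher number from compound 1 to compound 3 (0.28 log units; within the scatter) lies within it, a contrast that should not be read as a real difference between compound 3 and compound 4. Nothing available explains why isopropyl and iodo read alike here.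

The compounds shown leave open whether this position tolerates any group or only groups like these two, which an amine or a carboxylic acid in the same place would help to settle. They also leave open whether a longer chain there would keep the number in this range, or move it as far as the step between compound 1 and compound 2 did.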